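Methanesulfonamido for Methylsulfanyl: Expected Cytotoxicity

The source may report more compounds than this note shows. Statements on the series, on what has been measured and on what is new or still open speak of the compounds shown alone.

Three compounds with a shared core were tested in an ADME assay on PC-3 cells (Homo sapiens) for cytotoxicity, read by WST assay, tested at 100 uM; a higher number here means more inhibition at the concentration tested (going by the name of the read-out), a lower number less inhibition. Compound 1 `O=C(Nc1cccc(Oc2ccccn2)c1)C1CCCN(C(=O)c2cc(C(F)(F)F)cc(C(F)(F)F)c2)C1` gives 0%. Compound 2 `CSc1cccc(C(=O)N2CCCC(C(=O)Nc3ccc(Cl)cc3)C2)c1` gives 0%, and compound 3 `O=C(Nc1cccc(Cc2ccccc2)c1)C1CCCN(C(=O)c2cccc(-c3ccco3)c2)C1` gives 0%. Compound 2 thus stands level with compound 1 and compound 3 at the digits shown, all three within the usual scatter of one another, with no inhibition seen at the concentration tested. Compound 4 `CS(=O)(=O)Nc1cccc(C(=O)N2CCCC(C(=O)Nc3ccc(Cl)cc3)C2)c1` differs from compound 2 in one place: methanesulfonamido in place of methylsulfanyl on an aromatic carbon. Among the measured compounds shown here, no step between two measured compounds covers a change of this kind, so the expectation rests on the flat picture across compounds 1, 2 and 3. The expected step is no change at the digits printed from compound 2 to compound 4 (within the scatter), none beyond the scatter. Compound 4 is expected to give 0% in this assay, with a range from -10% to 12%.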

Compound 4, a percentage reported as inhibition, at one concentration (the size of the read-out at that concentration, not a potency): 3%
Compound 4: the middle estimate sits 3 percentage points below what was measured, within the range that was stated.
By their numbers in this assay, from the lowest: compounds 1, 2, 3 and 4 (each within the scatter of the next).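

In this assay, among the compounds shown here, placing methanesulfonamido instead of methylsulfanyl on this aromatic carbon, meta to a large group, gives a number 3 percentage points higher from compound 2 to compound 4 (within the scatter), the first single-place change that can be read here. This place on the ring can therefore carry the bigger group, with its hydrogen-bond donor, without the reading moving beyond the scatter. No measurement shown speaks to why the reading behaves this way. On these data alone, whether an amine or a carboxylic acid at this place would behave alike stays open, as do changes elsewhere on the shared core.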